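A few compounds are considered here, and "the series" means these few. Any claim that something is new, unique, unknown or untested is made for them only; others in the source may bear on it.

Notes on the series. Compound 1 `Cc1cnc(Nc2ccc([N+](=O)[O-])cc2)nc1Nc1nc2ccccc2s1` is tested in a functional assay on PC-3 cells (Homo sapiens) for antiproliferative activity, read by MTT assay, with a stated time of 48 h; on this read-out higher numbers stand for weaker inhibition and lower numbers for stronger inhibition. In this assay compound 1 gives only a limit, > 50000 nM, and not a number. Compound 2 `CS(=O)(=O)c1ccc(Nc2ncc(F)c(Nc3nc4ccc(F)cc4s3)n2)cc1` belongs to the same set. In this assay compound 2 likewise gives only a limit, > 50000 nM. For the measured compounds named here, both recorded values therefore sit at the limit of > 50000 nM in this assay, at which 2 of the 2 values shown sit, so compound 1 stands at the limit, with no measured step between it and any other compound and nothing beyond two equal limits to set it against compound 2.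

Compound 3 `Cc1cnc(Nc2ccc(C(C)C)cc2)nc1Nc1nc2ccccc2s1` is not yet measured. It differs from compound 1 in one place: isopropyl in place of nitro on an aromatic carbon. Cut one bond further out, the change reads 4-nitrophenyl to 4-isopropylphenyl. Going by the values given here, no measured step of this kind exists in the set, and no pair of numbers shows how the shared core answers to it, so no direction can be read from the data. The step is expected to be a number no higher from compound 1 to compound 3 (the limit leaves the size open), none beyond the scatter. For compound 3 the expected value in this assay is 50000 nM, within a range from 15000 nM to 100000 nM, and a limit rather than a number is the likelier report.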

Compound 3, half-maximal inhibitory concentration: > 50000 nM
Compound 3: no number, only a limit; the forecaster's own chance of this, stated with the estimate: 70%; the middle value sits exactly at the limit.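

In this assay compound 3 gives only a limit, > 50000 nM. For the compounds shown here, compound 1 also gives only a limit there, so no step between compound 1 and compound 3 can be read. The compounds shown leave open what number, if any, the shared core reaches in this assay and how far a single change moves it: the limit of > 50000 nM in this assay, at which 3 of the 3 values shown sit.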